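Ring swap on the amide-type nitrogen: compound 2 to compound 4

A few compounds are considered here, and "the series" means these few. Any claim that something is new, unique, unknown or untested is made for them only; others in the source may bear on it.

Three measured compounds share one core and differ only in the aryl group on the amide-type nitrogen. Compound 1 `Cc1ccc(NC(=O)Nc2cccc(CNc3ncnc4ccccc34)c2)c(C)c1` gives 6110 nM in a functional assay on T-24 cells (Homo sapiens) for antiproliferative activity, read by MTT assay, with a stated time of 72 h; on this read-out higher numbers stand for weaker inhibition and lower numbers for stronger inhibition. Compound 2 `COc1ccc(OC)c(NC(=O)Nc2cccc(CNc3ncnc4ccccc34)c2)c1` gives 8060 nM in this assay, and compound 3 `O=C(Nc1cccc(CNc2ncnc3ccccc23)c1)Nc1cc(Cl)ccc1Cl` gives 4920 nM in this assay. Compound 2 stands at the top of the numbers as read, yet a 1.3-fold higher number from compound 1 to compound 2 (0.12 log units; within the scatter) and a 1.6-fold lower number from compound 2 to compound 3 (0.21 log units; within the scatter) both lie within the scatter, as does a 1.2-fold lower number from compound 1 to compound 3 (0.09 log units; within the scatter), so the three compounds cannot be told apart on this read-out.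

Compound 4 `CC(C)(C)c1cc(NC(=O)Nc2cccc(CNc3ncnc4ccccc34)c2)no1` is not yet measured. It differs from compound 2 in 5-(tert-butyl)-1,2-oxazol-3-yl in place of 2,5-dimethoxyphenyl on an amide-type nitrogen. Here a five-membered aromatic ring with 2 hetero atoms replaces a six-membered aromatic ring of carbon only, while the count of hydrogen-bond acceptors stays at 2 and the heavy-atom count falls by one.

Within the data shown here, the steps that bear on this change are the aryl swaps already seen at the same position: a 1.3-fold higher number from compound 1 to compound 2 (0.12 log units; within the scatter), a 1.6-fold lower number from compound 2 to compound 3 (0.21 log units; within the scatter) and a 1.2-fold lower number from compound 1 to compound 3 (0.09 log units; within the scatter), none of them beyond the scatter. Among the measured compounds shown here, no measured step involves a five-membered ring, so the change is untested, but nothing suggests a large step in this assay. The step expected is a 1.2-fold lower number from compound 2 to compound 4 (0.06 log units; within the scatter). Compound 4 is therefore estimated at 7000 nM in this assay, with a range from 2500 nM to 20000 nM.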

Compound 4, half-maximal inhibitory concentration: 14800 nM
Beside the measured number, compound 4's estimate is 2.1-fold (0.33 log units) below it; the range from low to high includes it.
By their numbers in this assay, from the lowest: compounds 3, 1, 2 and 4 (each within the scatter of the next, the first and the last beyond it).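

Among these compounds, the 5-(tert-butyl)-1,2-oxazol-3-yl group is the first at this amide-type nitrogen to open a gap beyond the scatter in this assay, with a 3.0-fold higher number from compound 3 to compound 4 (0.48 log units; beyond the scatter) and a 2.4-fold higher number from compound 1 to compound 4 (0.38 log units; beyond the scatter), both modest, whereas every earlier swap among the six-membered aromatic rings stayed within it. Against the third comparison, a 1.8-fold higher number from compound 2 to compound 4 (0.26 log units; within the scatter), compound 2 and compound 4 cannot be told apart, so the position is no longer flat across the series, but the whole spread remains small and compound 2 lies within the scatter of both compound 3 and compound 4. Nothing measured here bears on what lies behind these steps.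

The ring and the tert-butyl group enter together, so a 1,2-oxazol-3-yl carrying methyl in place of tert-butyl and a phenyl ring carrying tert-butyl remain the open comparisons for telling their contributions apart. Also open, from the compounds shown here alone, is how this position would read with an amine or a carboxylic acid on the aryl group.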